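Carboxy to Ethoxycarbonyl: What to Expect for Compound 4

The source may report more compounds than this note shows. Statements on the series, on what has been measured and on what is new or still open speak of the compounds shown alone.

Measured so far in an assay for inhibition of 15-hydroxyprostaglandin dehydrogenase [NAD(+)] (Homo sapiens), read by fluorescence, with a stated time of 15 min, in the presence of a further agent that is not named here; on this read-out lower numbers stand for stronger inhibition and higher numbers for weaker inhibition:
compound 1 `CCC[S+]([O-])c1sc2nc(-c3cccs3)cc(C(=O)O)c2c1N` gives 71 nM;
compound 2 `CCCC[S+]([O-])c1sc2nc(-c3nccs3)cc(-c3cccc(CO)c3)c2c1N` gives 4.3 nM;
compound 3 `CCCC[S+]([O-])c1sc2nc(-c3nccs3)cc(-c3cnc(C)[nH]3)c2c1N` gives 2.3 nM.

Compound 1 carries the highest number of the three, hence the weakest inhibition, and its gaps to compound 2 and compound 3 both lie beyond the scatter. Compound 4 `CCC[S+]([O-])c1sc2nc(-c3cccs3)cc(C(=O)OCC)c2c1N` is compound 1 with ethyl in place of hydrogen on an oxygen next to a carbonyl group; read one bond further out, carboxy becomes ethoxycarbonyl. Among the compounds with values here, no measured step touches that group: the only measured step, a 1.9-fold lower number from compound 2 to compound 3 (0.27 log units; within the scatter), exchanges one ring for another at a different place on the shared core and lies within the scatter, so it offers no guide. Within the data shown here, with no directly comparable pair, compound 4 is expected to show a 2.1-fold higher number from compound 1 to compound 4 (0.32 log units; beyond the scatter), a modest weakening with wide uncertainty. Compound 4 is therefore estimated at 150 nM, within 30 nM to 800 nM.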

Compound 4, half-maximal inhibitory concentration: 2 nM
For compound 4 the middle estimate is 75-fold (1.88 log units) above the measured one, outside the stated range (below it).
By their numbers in this assay, from the lowest: compounds 4, 3 and 2 (each within the scatter of the next, the first and the last beyond it); then compound 1.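

Within the data shown here, putting ethyl on this oxygen, so that carboxy becomes ethoxycarbonyl, gives a 36-fold lower number from compound 1 to compound 4 (1.55 log units; beyond the scatter), the first measured step at this group. A small addition here can therefore change inhibition greatly, and on this core the hydrogen of the carboxy group is not needed for a low number. Nothing available explains why the step is so large.

Going by these compounds, it remains open whether a methyl group or a longer chain such as butyl on this oxygen would give a similar number. On these data alone, it is also open whether an amide in place of the ester would do so.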